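The source may report more compounds than this note shows. Statements on the series, on what has been measured and on what is new or still open speak of the compounds shown alone.

Working notes on the series. Compound 1 `COc1ccc(-c2c(Nc3ccc(F)cc3)c3ccccc3oc2=O)cc1` in a functional assay on MCF7 cells (Homo sapiens) for antiproliferative activity, read by MTT assay, with a stated time of 48 h (a lower number here means a stronger inhibitor, a higher number a weaker inhibitor), gives 38500 nM. Compound 2 `COc1ccc(-c2c(Nc3ccc(F)cc3)c3ccc(O)cc3oc2=O)cc1` in this assay gives 71500 nM. Among the compounds with values here, the one step measured so far, a 1.9-fold higher number from compound 1 to compound 2 (0.27 log units; within the scatter), puts compound 2 at the higher of the two numbers available, but that step sits within the scatter, so the two compounds cannot be ordered against each other. Compound 3 `COc1ccc(-c2c(Nc3ccc(NC(C)=O)cc3)c3ccc(O)cc3oc2=O)cc1` is the next member, differing from compound 2 only in one place: acetamido in place of fluoro on an aromatic carbon. No measured step bears on this exchange; the only step shown, a 1.9-fold higher number from compound 1 to compound 2 (0.27 log units; within the scatter), concerns a hydroxy in place of hydrogen on a different ring and is itself within the scatter. Nothing in the two values therefore argues for a change in either direction beyond the scatter, and the expectation for compound 3 is a number close to that of compound 2. The expected step is a 1.1-fold lower number from compound 2 to compound 3 (0.04 log units; within the scatter), judged as essentially no change. Within the data shown here, compound 3 is estimated at 65000 nM, with a range from 25000 nM to 180000 nM; the range is wide since only the single step of a 1.9-fold higher number from compound 1 to compound 2 (0.27 log units; within the scatter) has been measured.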

Compound 3, half-maximal inhibitory concentration: > 100000 nM
Compound 3 ended at the assay's limit; the forecaster's own chance of this, stated with the estimate: 20%; middle value at least 1.5-fold (0.18 log units) away from the limit.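

Compound 3 in this assay is recorded as a limit and not as a number: the limit of > 100000 nM in this assay, at which 1 of the 3 values shown sits. Within the data shown here, the earlier compounds all carry fluoro at this position, para to a large group, so the change from 4-fluorophenyl to 4-acetamidophenyl gives the first reading on what this position accepts, an at least 1.3-fold higher number from compound 2 to compound 3 (0.14 log units; that floor lies within the scatter). Going by these compounds, the reading gives only a floor for the step, so it shows no lower number with the larger acetamido group in place of fluoro, but it does not establish a loss beyond the scatter, and the true size of the step remains unknown.

The compounds shown leave open whether the loss, if real, comes from the amide hydrogen, the carbonyl, or simply the larger substituent, and a free amine or a carboxylic acid in place of acetamido, or a chloro group in place of fluoro, would help to separate these readings. They also leave open whether the same exchange reads alike on the core of compound 1, which lacks the hydroxy group, where a value clear of the limit would give the step a measurable size.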